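From Compound 2 to Compound 3: A Step Without a Yardstick

A few compounds are considered here, and "the series" means these few. Any claim that something is new, unique, unknown or untested is made for them only; others in the source may bear on it.

Compound 1, `O=C(C1CCCCC1)N1CCCN(C(c2ccccc2)c2ccccc2)CC1`: in an assay on isolated protein for binding affinity to Melanocortin receptor 4 (Homo sapiens) (a lower number here means a stronger inhibitor, a higher number a weaker inhibitor), compound 1 gives < 10000 nM, which is a limit of the assay rather than a number.
Compound 2, `CCCCNC(=O)N1CCCN(C(c2ccccc2)c2ccccc2)CC1`: in this assay compound 2 gives < 10000 nM, again a limit of the assay rather than a number.

Both readings sit at the same point, as the limit of < 10000 nM in this assay, at which 2 of the 2 values shown sit, records. Within the data shown here, the one change between them, butylamino in place of cyclohexyl on a carbonyl carbon, gives a step that the two limits leave unreadable from compound 1 to compound 2, so its size cannot be read. Compound 2 therefore stands only as a limit in this assay, with no number to compare against.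

Compound 3, `S=C(NC1CCCCC1)N1CCCN(C(c2ccccc2)c2ccccc2)CC1`, differs from compound 2 by a group of 9 heavy atoms (7 carbon, 1 nitrogen, 1 sulfur; one six-membered non-aromatic ring of carbon only) in place of a group of 7 heavy atoms (5 carbon, 1 nitrogen, 1 oxygen; no ring), on an amine nitrogen in a ring. Among the measured compounds shown here, no measured step bears on this change in a readable way, so no size or direction can be expected from the data. The step is expected to be a step that the limit leaves unreadable from compound 2 to compound 3 only in the sense that compound 3 is expected to stay within the region the limits mark out. The estimate for compound 3 in this assay is 3000 nM, expected to fall between 300 nM and 10000 nM.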

Compound 3, inhibition constant: < 10000 nM
Compound 3 gave a limit, no number (the forecaster's own chance of this, stated with the estimate: 60%); the middle value does not contradict the limit.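

In this assay compound 3 gives < 10000 nM, again a limit of the assay and not a number. The steps among compound 1, compound 2 and compound 3 therefore cannot be read, and all three readings stand at one point: the limit of < 10000 nM in this assay, at which 3 of the 3 values shown sit.

Going by these compounds, the actual strength of each compound remains open, as does whether the changes among them alter it at all.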